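A few compounds are considered here, and "the series" means these few. Any claim that something is new, unique, unknown or untested is made for them only; others in the source may bear on it.

Working notes on the series. Among the measured compounds shown here, in an ADME assay on microsomes from liver (Homo sapiens) for metabolic stability (on this read-out higher numbers stand for a longer-lived compound and lower numbers for a shorter-lived compound), compound 1 (`CC#C[C@@H](Cc1nnn[nH]1)c1ccc(OCc2ccc3scc(-c4cc(OCCOC)ccc4C)c3c2)cc1`) gives 0.867 h, the highest of the three numbers so far. Compound 2 (`CC#C[C@@H](Cc1nnn[nH]1)c1ccc(OCc2cc(Cl)c3scc(-c4ccccc4C)c3c2)cc1`) gives 0.217 h and compound 3 (`CC#C[C@@H](Cc1nnn[nH]1)c1ccc(OCc2ccc3sc(C#N)c(-c4ccccc4C)c3c2)cc1`) gives 0.0333 h, each lower than compound 1 by more than the scatter. These three compounds differ from one another in more than one place, so no gap among them can be assigned to a single group.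

The unmeasured compound is compound 4 (`CC#C[C@@H](Cc1nnn[nH]1)c1ccc(OCc2ccc3scc(-c4cncnc4C)c3c2)cc1`). It carries 4-methylpyrimidin-5-yl in place of 5-(2-methoxyethoxy)-2-methylphenyl, on an aromatic carbon of a five-membered aromatic ring with 1 sulfur, two ring bonds from the ring sulfur (4-methylpyrimidin-5-yl in place of 5-(2-methoxyethoxy)-2-methylphenyl on an aromatic carbon).

For the measured compounds named here, no measured pair isolates a change at this place, so the size of the step in this assay has no direct precedent. The working expectation is a small rise that stays within the scatter, with a fall of similar size not excluded. The anchor is compound 1 at 0.867 h. The estimated step is a 1.5-fold higher number from compound 1 to compound 4 (0.18 log units; within the scatter). For compound 4 the expected value is 1.3 h, with an estimated range of 0.4 h to 4 h.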

Compound 4, half-life: 0.233 h
Compound 4: middle estimate off by 5.6-fold (0.75 log units), on the high side, and the stated range ends above it.
By their numbers in this assay, from the lowest: compound 3; then compounds 2 and 4 (each within the scatter of the next); then compound 1.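

In this assay, among the compounds shown here, 4-methylpyrimidin-5-yl in place of 5-(2-methoxyethoxy)-2-methylphenyl gives a 3.7-fold lower number from compound 1 to compound 4 (0.57 log units; beyond the scatter), the only step that isolates one place, and it lies beyond the scatter. For the compounds shown here, the aromatic carbon two ring bonds from the ring sulfur is therefore a place where the choice of group shows up in the half-life, which the earlier compounds, differing in more than one place, could not show. The change removes the 2-methoxyethoxy chain and replaces a ring of carbon only with a ring holding two hetero atoms, and no information on what lies behind the step is at hand.

Going by these compounds alone, the single step cannot separate the loss of the chain from the change of ring, so neither part can be credited with the shorter half-life. On these data alone, a pyridine ring, or a pyrimidine ring carrying the 2-methoxyethoxy chain, at this place would be the kind of group that could divide the step, and whether a hydroxyethoxy chain or an amine on the phenyl ring would hold the half-life of compound 1 remains open.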